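Swapping the Acid-Bearing Ring for a Thiazole Acid

The source may report more compounds than this note shows. Statements on the series, on what has been measured and on what is new or still open speak of the compounds shown alone.

Compound 1 `O=C(N[C@H]1CC[C@H](C(=O)O)CC1)[C@H](C1CCCCC1)n1c(-c2ccc(Cl)nc2)nc2cc(F)c(F)cc21` gives 1700 nM in an assay on isolated protein for displacement of a labelled ligand from Bile acid receptor (Homo sapiens), read by scintillation proximity assay and radioligand binding; on this read-out lower numbers stand for stronger inhibition and higher numbers for weaker inhibition.
Compound 2 `O=C(O)c1cccc(NC(=O)C(C2CCCCC2)n2c(-c3ccc(Cl)cc3)nc3cc(F)c(F)cc32)c1` gives 1300 nM in this assay.
Compound 3 `O=C(O)Cc1ccc(NC(=O)C(C2CCCCC2)n2c(-c3ccc(Cl)cc3)nc3cc(F)c(F)cc32)cc1` gives 1400 nM in this assay.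

Compound 3 has the second highest of these three numbers, yet its gaps to compound 2 and to compound 1 both lie within the usual scatter, so none of the three can be called stronger or weaker than another.

Compound 4 `Cc1nc(NC(=O)C(C2CCCCC2)n2c(-c3ccc(Cl)cc3)nc3cc(F)c(F)cc32)sc1C(=O)O` has not been measured. It differs from compound 3 by 5-carboxy-4-methyl-1,3-thiazol-2-yl in place of 4-(carboxymethyl)phenyl on an amide-type nitrogen. For the measured compounds named here, only one measured step touches the same place: a 1.1-fold higher number from compound 2 to compound 3 (0.03 log units; within the scatter), a change of the acid-bearing ring that left the number essentially unmoved. Going by the values given here, no measured step exchanges a six-membered carbon ring for a five-membered ring with hetero atoms, so the expectation rests on that single step. A step of no change at the digits printed from compound 3 to compound 4 (within the scatter) is therefore expected, none beyond the scatter. Compound 4 is estimated at 1400 nM, within a range from 500 nM to 4000 nM.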

Compound 4, half-maximal inhibitory concentration: 90 nM
Compound 4: middle estimate off by 16-fold (1.19 log units), on the high side; the whole stated range lies above it.
By their numbers in this assay, from the lowest: compound 4; then compounds 2, 3 and 1 (each within the scatter of the next).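

The group on the amide-type nitrogen matters more than the two carbon-ring acids suggested, since they sit within the scatter of each other. With 5-carboxy-4-methyl-1,3-thiazol-2-yl, stronger inhibition appears in this assay as a 16-fold lower number from compound 3 to compound 4 (1.19 log units; beyond the scatter) and as a 14-fold lower number from compound 2 to compound 4 (1.16 log units; beyond the scatter) on the same change of ring. Nothing available explains this gain.

The new ring and its methyl arrive together, so their shares stay unseparated. The same ring without the methyl, or with a carboxymethyl in place of the carboxylic acid, would test each part.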